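Methyl in Place of 4-Methylphenyl: Two Matched Pairs

The compounds below may be only part of what the source reports. "The series", "measured", "known", "first", "only" and "open" are said of these compounds alone.

Three compounds have been measured in an assay on isolated protein for inhibition of STE20-like serine/threonine-protein kinase (Homo sapiens), read by thermal shift assay, tested at 10 uM; a higher number here means that the compound stabilises the target more against heat, a lower number that the compound stabilises the target less:

Compound 1, `Cc1ccc(-n2nc(C(C)(C)C)cc2NC(=O)Nc2cc(C(F)(F)F)cc(C(F)(F)F)c2)cc1`: 0 degrees C
Compound 2, `Cn1nc(C(C)(C)C)cc1NC(=O)Nc1cc(C(F)(F)F)cc(C(F)(F)F)c1`: 2.4 degrees C
Compound 3, `Cc1ccc(-n2nc(C(C)(C)C)cc2NC(=O)Nc2cc(F)cc(F)c2)cc1`: 2.8 degrees C

Compound 1 and compound 2 differ in one place only, (methyl in place of 4-methylphenyl on an aromatic nitrogen). That single change gives a number 2.4 degrees C higher from compound 1 to compound 2 (beyond the scatter). Compound 3 carries the same 4-methylphenyl group on its ring nitrogen as compound 1, but its core is otherwise different; the difference between the two cores is not broken down here. In this assay compound 3 gives 2.8 degrees C, which lies beyond the scatter from compound 1, while the gap to compound 2 stays within the scatter, so no order between compound 2 and compound 3 can be read from these numbers.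

Compound 4, `Cn1nc(C(C)(C)C)cc1NC(=O)Nc1cc(F)cc(F)c1`, has not yet been measured. It stands to compound 3 as compound 2 stands to compound 1: methyl in place of 4-methylphenyl on an aromatic nitrogen. This is the same change, at the same place, as the one already seen. For the measured compounds named here, it is expected that compound 4 will move by about a number 1.7 degrees C higher from compound 3 to compound 4 (beyond the scatter), because the single earlier instance of this change gave a number 2.4 degrees C higher from compound 1 to compound 2 (beyond the scatter). Going by the values given here, on that basis the estimate for compound 4 in this assay is 4.5 degrees C. Since only one earlier pair supports the expectation, and the starting point of compound 3 is already higher than that of compound 1, the estimate for compound 4 is given a wide band, from 2.5 degrees C to 6.5 degrees C.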

Compound 4, shift of the target's melting temperature: 1.2 degrees C
Compound 4: middle estimate off by 3.3 degrees C, on the high side; measured number outside the range, below it.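

On the core of compound 3, the change from 4-methylphenyl to methyl on the aromatic nitrogen gives a number 1.6 degrees C lower from compound 3 to compound 4 (beyond the scatter), whereas the same change raised the number on the core of compound 1. In this assay, the effect of this change therefore does not carry from one core to the other, and even its direction is reversed: the same change on two cores in this assay, a number 2.4 degrees C higher (beyond the scatter) from compound 1 to compound 2 and a number 1.6 degrees C lower (beyond the scatter) from compound 3 to compound 4, 4.0 degrees C apart, beyond the scatter of two such steps These two pairs show that, within this series, a result for this change on one core cannot be taken as a guide to its result on another, but they do not show which difference between the cores lies behind the reversal, nor how the change would behave on any third core.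

The compounds shown leave open how an ethyl group or an unsubstituted phenyl group on the same ring nitrogen would read on each core, and so whether the numbers move gradually or abruptly between the two groups compared here. They also leave open which way the change would go on a core carrying chlorine in place of the fluorine atoms of compound 3, or a single trifluoromethyl group in place of the two in compound 1.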